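A Chloro Group Added to the Ring of Compound 2

A few compounds are considered here, and "the series" means these few. Any claim that something is new, unique, unknown or untested is made for them only; others in the source may bear on it.

Compound 1 `COc1ccc(N2C[C@@H](C)N[C@@H](C)C2)cc1NS(=O)(=O)c1ccc(-c2cc(Cl)ccc2F)cc1` and compound 2 `COc1ccc(N2C[C@@H](C)N[C@@H](C)C2)cc1NS(=O)(=O)c1ccc(-c2cccs2)cc1` share a common core and differ in one place only. In a functional assay for agonist activity at growth hormone secretagogue receptor type 1 (Homo sapiens), read by FLIPR (on this read-out higher numbers stand for an effect only at larger amounts of compound and lower numbers for an effect already at smaller amounts), compound 1 gives 0.501 nM, while compound 2 gives 3.98 nM. For the measured compounds named here, the step of a 7.9-fold higher number from compound 1 to compound 2 (0.90 log units; beyond the scatter) sets compound 2 at the higher of the two numbers, with compound 1 as its only neighbour.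

Compound 3 `COc1ccc(N2C[C@@H](C)N[C@@H](C)C2)cc1NS(=O)(=O)c1ccc(-c2cccs2)cc1Cl` differs from compound 2 by chloro in place of hydrogen on an aromatic carbon; the new chlorine sits ortho to a large group and meta to a thiophen-2-yl group. Going by the values given here, no measured step touches this place: the only step seen, a 7.9-fold higher number from compound 1 to compound 2 (0.90 log units; beyond the scatter), swaps the distal aromatic group instead, so it offers no direct guide. Without such a precedent, the expected step in this assay is small, a 1.3-fold lower number from compound 2 to compound 3 (0.12 log units; within the scatter), in no firm direction. Compound 3 is therefore estimated at 3 nM, with a range from 0.8 nM to 12 nM.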

Compound 3, half-maximal effective concentration: 0.794 nM
Compound 3: middle estimate off by 3.8-fold (0.58 log units), on the high side; the measured number lies below the stated range.
By their numbers in this assay, from the lowest: compounds 1 and 3 (each within the scatter of the next); then compound 2.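

In this assay, this place on the six-membered aromatic ring, ortho to a large group and meta to the thiophen-2-yl group, proves sensitive to change: chloro in place of hydrogen gives a 5.0-fold lower number from compound 2 to compound 3 (0.70 log units; beyond the scatter), a step beyond the scatter. For the compounds shown here, the earlier pair differed only in the distal aromatic group, so this is the first sign that the ring carrying that group also matters, and a single chlorine atom is enough to shift the number. Nothing available explains why this small change has such an effect.

From the compounds shown here alone, whether the step depends on chlorine itself remains open, since a fluoro, methyl, methoxy or amino group at this place could show how specific it is. It is also unknown whether the same chloro change would carry over when 5-chloro-2-fluorophenyl replaces thiophen-2-yl.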